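The compounds below may be only part of what the source reports. "The series", "measured", "known", "first", "only" and "open" are said of these compounds alone.

Measured compounds:
compound 1, `CCCC1=C(OC)C(CCC)(CCC)C(=O)/C(=C(O)\C=C\c2ccccc2)C1=O` — 3.7 uM
compound 2, `CCCC1=C(OCCC(C)C)C(CCC)(CCC)C(=O)/C(=C(O)\C=C\c2ccccc2)C1=O` — "not determined" (no result reported)

In a functional assay on 1A9 cells (Homo sapiens) for antiproliferative activity, read by sulforhodamine B assay, with a stated time of 3 days (a higher number here means that more compound is needed for the effect, a lower number that less compound is needed), compound 1 gives 3.7 uM. Compound 2 was run in the same series but no result was reported for it in this assay, so compound 1 stands alone with the only number shown, and there is no measured pair from which the size of any step could be read.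

Compound 3, `CCCC1=C(OC)C(CCC)(CCC)C(=O)/C(=C(O)\C=C\c2ccc(Br)cc2)C1=O`, is the next compound to be measured. Its structure differs from compound 1 in exactly one place: bromo in place of hydrogen on an aromatic carbon. The rest of the molecule, the shared core with its chains and the ethenyl linker, is unchanged.

Going by the values given here, with no measured step available, the expectation rests on the small size of the change alone. A single bromine entering on the outer aromatic ring is expected to shift the concentration for half-maximal effect only slightly, most likely within or close to the usual scatter, with a mild lean toward less compound being needed. Compound 3 is therefore expected to give 2.8 uM, within 0.9 uM to 9 uM, which from compound 1 to compound 3 would mean an estimated step of a 1.3-fold lower number from compound 1 to compound 3 (0.12 log units; within the scatter).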

Compound 3, concentration for half-maximal effect: 1.9 uM
Compound 3: the middle estimate sits 1.5-fold (0.17 log units) above what was measured; low and high end bracket the measured number.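

Going by these compounds alone, this is the first measured step, and it falls on the outer phenyl ring: in this assay, putting bromo in place of hydrogen on this aromatic carbon gives a 1.9-fold lower number from compound 1 to compound 3 (0.29 log units; within the scatter) as the step. The position therefore accepts a bromine, a single heavy atom added to the end of the 2-phenylethenyl group, while the two compounds remain indistinguishable in this test, so the result counts neither as a real gain nor as a real loss. No measurement available here accounts for this outcome.

Going by these compounds, whether this same place would accept a different group, such as a methoxy group, an amine or a carboxylic acid, remains open, as does whether bromo would give a similar result elsewhere on the phenyl ring. On these data alone, the step to compound 2, with its longer ether chain, cannot be read without a number, so the effect of changing that side of the shared core also remains unknown.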